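Swapping a Difluorobenzyl Group for a Pyridinylpropyl Chain

This account rests on a few compounds, and the source may have more. Where it says the series, first, only, none or still open, it means among the compounds named here.

Measured compounds:
- compound 1 `Ic1ccc(Cn2cc(CCCOc3cccc4cccnc34)nn2)cc1`: > 250 ug/mL in a functional assay on NCI/ADR-RES cells (Homo sapiens) for inhibition, read by sulforhodamine B assay, with a stated time of 48 h; on this read-out lower numbers stand for stronger inhibition of growth and higher numbers for weaker inhibition of growth
- compound 2 `FC(F)(F)Oc1ccc(Cn2cc(CCCOc3cccc4cccnc34)nn2)cc1`: 5.5 ug/mL
- compound 3 `Fc1ccc(Cn2cc(CCCOc3cccc4cccnc34)nn2)cc1F`: 42.1 ug/mL

Compound 1 gives only a limit in this assay, so no number is known for it (the limit of > 250 ug/mL in this assay, at which 1 of the 3 values shown sits). Among the two numbers shown, compound 3 has the highest; its nearest neighbour is compound 2, which sits beyond the scatter below it. Both measured steps start from the limit of compound 1: an at least 45-fold lower number from compound 1 to compound 2 (1.65 log units; beyond the scatter) and an at least 5.9-fold lower number from compound 1 to compound 3 (0.77 log units; beyond the scatter), each of them beyond the scatter.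

Compound 4 `c1cncc(CCCn2cc(CCCOc3cccc4cccnc34)nn2)c1` differs from compound 3 in one place: 2-(pyridin-3-yl)ethyl in place of 3,4-difluorophenyl on a saturated chain carbon bound to an aromatic nitrogen. Going by the values given here, no measured step covers this change. The two steps shown only say that the group on the saturated chain carbon bound to the aromatic nitrogen can move the read-out strongly; they do not tell in which direction a pyridinyl chain goes. The estimate for compound 4 is therefore wide: a value around 70 ug/mL, between 12 ug/mL and 250 ug/mL, meaning an expected step of a 1.7-fold higher number from compound 3 to compound 4 (0.22 log units; within the scatter), with a real chance that only a limit is reported.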

Compound 4, concentration for 50% growth inhibition: 12.5 ug/mL
Compound 4: the middle estimate sits 5.6-fold (0.75 log units) above what was measured, and the stated range covers the measured number.
By their numbers in this assay, from the lowest: compound 2; then compound 4; then compound 3. At a limit, above all of these: compound 1.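

Replacing 3,4-difluorobenzyl with 3-(pyridin-3-yl)propyl gives a 3.4-fold lower number from compound 3 to compound 4 (0.53 log units; beyond the scatter) in this assay. Going by these compounds alone, the group on the saturated chain carbon bound to an aromatic nitrogen therefore need not be a substituted benzyl group for growth inhibition to be seen, something the earlier compounds, all substituted benzyl groups, could not show. Against compound 1 the same place gives an at least 20-fold lower number from compound 1 to compound 4 (1.30 log units; beyond the scatter), but that step is only a bound, since compound 1 has a limit and not a number: the limit of > 250 ug/mL in this assay, at which 1 of the 4 values shown sits.

From the compounds shown here alone, the longer chain and the pyridine ring change together in this step, so what each contributes remains open. A 3-phenylpropyl group or a pyridin-3-ylmethyl group at this place would separate the two.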